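Shortening the side chain of compound 3

The compounds below may be only part of what the source reports. "The series", "measured", "known", "first", "only" and "open" are said of these compounds alone.

In a functional assay on EOL1 cells (Homo sapiens) for inhibition, read by fluorescence, with a stated time of 72 h (on this read-out lower numbers stand for stronger inhibition of growth and higher numbers for weaker inhibition of growth), compound 1 `CC(C)CCn1cnc2c(Nc3ccc(Cl)cc3)nc(N[C@H]3CC[C@H](N)CC3)nc21` gives 90 nM and compound 2 `CCCCn1cnc2c(Nc3ccc(Cl)cc3)nc(N[C@H]3CC[C@H](N)CC3)nc21` gives 50 nM while compound 3 `CC(C)CCn1cnc2c(Nc3ccccc3)nc(N[C@H]3CC[C@H](N)CC3)nc21` gives 10 nM as the lowest number of the three. Not yet measured, compound 4 `CCCCn1cnc2c(Nc3ccccc3)nc(N[C@H]3CC[C@H](N)CC3)nc21` differs from compound 3 by hydrogen in place of methyl on a saturated chain carbon bound to two saturated chain carbons in one place, with hydrogen in place of methyl on a saturated chain carbon bound to two saturated chain carbons, so isopentyl becomes butyl. The same change between the two chloro compounds is the step of a 1.8-fold lower number from compound 1 to compound 2 (0.26 log units; within the scatter) and stays within the scatter. The larger step of a 9.0-fold lower number from compound 1 to compound 3 (0.95 log units; beyond the scatter) removes chloro, a change not made here. Hence no step beyond the scatter is expected, and the estimated change is a 1.4-fold lower number from compound 3 to compound 4 (0.15 log units; within the scatter) on this read-out. For compound 4 the expected value is 7 nM with 3 nM to 18 nM as its estimated range.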

Compound 4, concentration for 50% growth inhibition: 20 nM
The estimate for compound 4 lay 2.9-fold (0.46 log units) below the measured number, outside the stated range (above it).
By their numbers in this assay, from the lowest: compounds 3 and 4 (each within the scatter of the next); then compounds 2 and 1 (each within the scatter of the next).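

Isopentyl to butyl gives a 2.0-fold higher number from compound 3 to compound 4 (0.30 log units; within the scatter) in this assay, so on the core without chloro this chain change also stays within the scatter, yet it does not match the step on the chloro compounds: the same change on two cores in this assay, a 1.8-fold lower number (0.26 log units; within the scatter) from compound 1 to compound 2 and a 2.0-fold higher number (0.30 log units; within the scatter) from compound 3 to compound 4, 3.6-fold (0.56 log units) apart, beyond the scatter of two such steps

Hydrogen in place of chloro lowers the number with butyl too, by a 2.5-fold lower number from compound 2 to compound 4 (0.40 log units; beyond the scatter), but by less than with isopentyl: the same change on two cores in this assay, a 9.0-fold lower number (0.95 log units; beyond the scatter) from compound 1 to compound 3 and a 2.5-fold lower number (0.40 log units; beyond the scatter) from compound 2 to compound 4, 3.6-fold (0.56 log units) apart, beyond the scatter of two such steps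

The compounds shown leave open how a longer chain such as hexyl, or a shorter one such as propyl, would read on either core. They also leave open what fluoro or methoxy in place of chloro would do.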